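This account rests on a few compounds, and the source may have more. Where it says the series, first, only, none or still open, it means among the compounds named here.

Among the compounds with values here, in a functional assay on the whole organism (Mus musculus) for inhibition, at a dose of 150 mg/kg by the oral route (on this read-out higher numbers stand for more inhibition at the one dose given (going by the name of the read-out) and lower numbers for less inhibition), compound 1 `Cc1cc(S(=O)(=O)NC(=O)Nc2ccc(Cl)cc2)cc2ccoc12` gives 89%, the highest of the two numbers measured so far; compound 2 `Cc1ccc2oc(S(=O)(=O)NC(=O)Nc3ccc(Cl)cc3)cc2c1` gives 6%, a gap from compound 1 that lies beyond the scatter. Within the data shown here, no pair of measured compounds differs in one place, so the change to compound 3 `COc1cc(S(=O)(=O)NC(=O)Nc2ccc(Cl)cc2)cc2ccoc12` has no measured counterpart. Compound 3 differs from compound 1 by methoxy in place of methyl on an aromatic carbon. With one carbon kept and one oxygen added, only a small step is expected, a number 14 percentage points lower from compound 1 to compound 3 (beyond the scatter), probably within the scatter and toward less inhibition if anything. Compound 3 is expected near 75%, in the range 40% to 95%.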

Compound 3, a percentage reported as inhibition, in the whole organism at one dose (the size of the read-out at that dose, not a potency): 51%
Compound 3: middle estimate off by 24 percentage points, on the high side; the range from low to high includes it.
By their numbers in this assay, from the lowest: compound 2; then compound 3; then compound 1.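

At this position, an aromatic carbon of the six-membered ring of the core, the read-out in this assay proves sensitive to the group carried: methoxy in place of methyl gives a number 38 percentage points lower from compound 1 to compound 3 (beyond the scatter), a large step. Within the data shown here, this is the first one-place comparison, and of these two groups methyl gives the higher number. No measurement bears on the reason for this step.

Open, from the compounds shown here alone, is where hydrogen, ethyl, hydroxy or an amine at this position would fall relative to compound 1 and compound 3.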